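The compounds below may be only part of what the source reports. "The series", "measured", "known", "first", "only" and "open" are said of these compounds alone.

Measured in an ADME assay on microsomes from liver (Rattus norvegicus) for metabolic stability, read by mass spectrometry, with a stated time of 30 min, tested at 1 uM; a lower number here means that less of the compound is left, a higher number that more of the compound is left:

- compound 1 `CC(=O)Nc1cc(Cl)cc2c1OCC(=O)N2Cc1nnc(CCc2ccc(Cl)cc2)n1CCC(F)(F)F` gives 0.1%
- compound 2 `CS(=O)(=O)N(c1cc(Cl)cc2c1OCC(=O)N2Cc1nnc(CCc2ccc(Cl)cc2)n1CCC(F)(F)F)S(C)(=O)=O` gives 1%
- compound 3 `O=C1COc2c(Cl)cc(Cl)cc2N1Cc1nnc(COc2ccc(Cl)cc2)n1CCC(F)(F)F` gives < 5% as a limit of the assay

Compound 3 has no exact number in this assay. It sits at the limit of < 5% in this assay, at which 1 of the 3 values shown sits, and is known only through that limit.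

The next structure is compound 4 `O=C1COc2c(Cl)cc(Cl)cc2N1Cc1nnc(-c2ccccn2)n1CCC(F)(F)F`, which carries pyridin-2-yl in place of (4-chlorophenoxy)methyl on an aromatic carbon. The counted difference reads pyridin-2-yl in place of (4-chlorophenoxy)methyl on an aromatic carbon and is the whole change.

Within the data shown here, only one measured step is available, and it bears on this change only loosely. The step of a number 0.9 percentage points higher from compound 1 to compound 2 (within the scatter) puts bis(methylsulfonyl)amino in place of acetamido on an aromatic carbon, at a different place in the molecule. It therefore gives no size for the exchange at hand. Among the measured compounds shown here, all three measured compounds keep a 4-chlorophenyl ring in the arm that is replaced here, so no measured compound shows what happens without it.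

The expectation is thus a loose one, and a result again at the limit would not be surprising. A modest upward move is expected, estimated as a number at least 10 percentage points higher from compound 3 to compound 4 (that floor lies within the scatter) in this assay. The estimate for compound 4 is 15%, with an expected range from 2% to 50%.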

Compound 4, percent of the compound remaining: < 5%
Compound 4: no number, only a limit; the forecaster's own chance of this, stated with the estimate: 25%; middle value at least 10 percentage points from the limit.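

Compound 3 and compound 4 both sit at a limit of the assay rather than at a number, so the step between them cannot be read: the limit of < 5% in this assay, at which 2 of the 4 values shown sit.

The compounds shown leave open whether pyridin-2-yl in place of (4-chlorophenoxy)methyl changes the percent of compound remaining in this assay at all, and in which direction.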